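Removing the chloro group from the octanediamide analogue

The compounds below may be only part of what the source reports. "The series", "measured", "known", "first", "only" and "open" are said of these compounds alone.

In an assay on GL26 cells for inhibition of Amine oxidase [flavin-containing] A (Homo sapiens), read by scintillation counting, with a stated time of 20 min (a lower number here means a stronger inhibitor, a higher number a weaker inhibitor), compound 2 `C#CCN(C)CCCOc1cc(NC(=O)CCCCCCC(=O)NO)c(Cl)cc1Cl` gives 430 nM, the highest number of the three measured, with compound 1 `C#CCN(C)CCCOc1cc(NCc2ccc(/C=C/C(=O)NO)cc2)ccc1Cl` giving 4 nM and compound 3 `C#CCN(C)CCCOc1cc(NCc2ccc(C(=O)NO)cc2)ccc1Cl` giving 0.4 nM. Compound 4 `C#CCN(C)CCCOc1cc(NC(=O)CCCCCCC(=O)NO)ccc1Cl` differs from compound 2 by hydrogen in place of chloro on an aromatic carbon. Among the measured compounds shown here, no measured pair shows this change on its own: the one single-point step, a 10-fold lower number from compound 1 to compound 3 (1.00 log units; beyond the scatter), alters the hydroxamate end of the molecule, and both of its compounds already carry a single chloro group. Nothing measured therefore bears directly on removing the chloro group from compound 2, and the expectation is a change within the scatter, a 1.4-fold lower number from compound 2 to compound 4 (0.16 log units; within the scatter). Compound 4 is expected to give 300 nM in this assay, with a range from 90 nM to 1000 nM.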

Compound 4, half-maximal inhibitory concentration: 3250 nM
Estimate against measurement, compound 4: 11-fold (1.03 log units) below; the whole stated range lies below it.
By their numbers in this assay, from the lowest: compound 3; then compound 1; then compound 2; then compound 4.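

The position para to the 3-(methyl(propargyl)amino)propoxy group is not silent in this assay: hydrogen in place of chloro gives a 7.6-fold higher number from compound 2 to compound 4 (0.88 log units; beyond the scatter), so here the chloro group goes with the lower number. Among the compounds shown here, this is the first single-point step away from the hydroxamate end of the series. Nothing available explains this step.

As far as these compounds go, whether a fluoro, bromo or methyl group at this position would match chloro remains open. So does whether a second chloro group would also lower the numbers of compound 1 and compound 3.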